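The source may report more compounds than this note shows. Statements on the series, on what has been measured and on what is new or still open speak of the compounds shown alone.

Three compounds carry measurements in an ADME assay on HEK293 cells (Homo sapiens) for inhibition, with a stated time of 72 h; on this read-out higher numbers stand for an effect only at larger amounts of compound and lower numbers for an effect already at smaller amounts. Compound 1 `O=C(Nc1ccc(Cl)cc1)c1cc([N+](=O)[O-])ccc1Cl` has an amide bearing a chlorinated nitrophenyl group. In this assay compound 1 gives > 25000 nM, which is a limit of the assay and not a number. Compound 2 `C=CC(=O)Nc1cccc(-c2nc3ccccc3s2)c1` carries an acrylamide on a shared core. In this assay compound 2 gives > 25000 nM, again only a limit. Compound 3 `O=C(O)/C=C/C(=O)Nc1cccc(-c2nc3ccccc3s2)c1` keeps that core with a carboxylic acid on the olefin. In this assay compound 3 gives > 25000 nM, likewise a limit. The step from compound 2 to compound 3 is therefore a step that the two limits leave unreadable from compound 2 to compound 3, and compound 3 stands at the limit of > 25000 nM in this assay, at which 3 of the 3 values shown sit, where every value in this set sits.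

Compound 4 `O=C(Nc1cccc(-c2nc3ccccc3s2)c1)c1cnccc1Cl` differs from compound 3 by 4-chloropyridin-3-yl in place of 2-carboxyethenyl on a carbonyl carbon. Within the data shown here, no measured step bears on this exchange, because the only step known, a step that the two limits leave unreadable from compound 2 to compound 3, cannot be read at all. Given that compound 3 sits at the limit of > 25000 nM in this assay, at which 3 of the 3 values shown sit, compound 4 is expected to return a limit as well, with a step that the limit leaves unreadable from compound 3 to compound 4. The estimate for compound 4 in this assay is 30000 nM, within a range from 8000 nM to 100000 nM.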

Compound 4, half-maximal effective concentration: > 25000 nM
Compound 4: no number, only a limit; the forecaster's own chance of this, stated with the estimate: 75%; the middle value does not contradict the limit.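

Compound 4 also ends at a limit in this assay, so its exchanges against compound 2 and compound 3 cannot be read, and no step size follows from either: the limit of > 25000 nM in this assay, at which 4 of the 4 values shown sit. The compounds shown leave open whether any group on that carbonyl carbon would give a number rather than a limit in this assay.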